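Carbamate series: chain end from phenyl to heptyl

The compounds below may be only part of what the source reports. "The series", "measured", "known", "first", "only" and "open" are said of these compounds alone.

Working notes on a small set. Compound 1 `CC(C)c1cccc(C(C)C)c1NC(=O)NC(=O)OC(c1ccccc1)c1ccccc1` in an assay on microsomes from intestine for inhibition of acyl-CoA:cholesterol acyltransferase (Oryctolagus cuniculus) (on this read-out higher numbers stand for weaker inhibition and lower numbers for stronger inhibition), gives 7800 nM. Compound 2 `COC(=O)C(OC(=O)NC(=O)Oc1c(C(C)C)cccc1C(C)C)c1ccccc1` in this assay gives 940 nM. Compound 3 `CC(C)c1cccc(C(C)C)c1OC(=O)NC(=O)OCCCc1ccccc1` in this assay gives 660 nM, the lowest number of the three; its gap to compound 2 lies within the scatter, so these two cannot be ordered, while compound 1 sits clearly above both.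

Compound 4 `CCCCCCCCCCOC(=O)NC(=O)Oc1c(C(C)C)cccc1C(C)C` differs from compound 3 by heptyl in place of phenyl on a saturated chain carbon, three bonds along the chain from an oxygen next to a carbonyl group. Within the data shown here, no measured pair in the set shows this kind of change, so its direction rests on the spread of the set alone. Because compound 2 at 940 nM and compound 3 at 660 nM sit close together with different chain ends, the expected change is a 1.3-fold lower number from compound 3 to compound 4 (0.12 log units; within the scatter), small and within the scatter, with a modest gain not excluded. The estimate for compound 4 in this assay is 500 nM, with a range from 150 nM to 1600 nM.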

Compound 4, half-maximal inhibitory concentration: 74 nM
For compound 4 the middle estimate is 6.8-fold (0.83 log units) above the measured one, outside the stated range (below it).
By their numbers in this assay, from the lowest: compound 4; then compounds 3 and 2 (each within the scatter of the next); then compound 1.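

In this assay, the replacement of phenyl by heptyl on a saturated chain carbon, three bonds along the chain from an oxygen next to a carbonyl group, gives an 8.9-fold lower number from compound 3 to compound 4 (0.95 log units; beyond the scatter), so this position responds clearly to what it carries. In this pair, an aromatic ring at the chain end is not required for inhibition: the open heptyl chain gives the lower number, and neither group brings hydrogen-bond donors, acceptors or a net charge. No measurement at hand bears on the cause of this step.

This single pair does not separate the loss of the ring from the change in chain shape and length; a cyclohexyl end, a pentyl chain and a decyl chain would address this. From the compounds shown here alone, whether the position also accepts an amine or a carboxylic acid at the chain end remains open.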